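The compounds below may be only part of what the source reports. "The series", "measured", "known", "first", "only" and "open" are said of these compounds alone.

Measured so far in a functional assay on MGC-803 cells (Homo sapiens) for inhibition, read by MTT assay, with a stated time of 72 h; a higher number here means a weaker inhibitor, a lower number a stronger inhibitor:
compound 1 `CC(C)c1ccc(-c2nc(SCc3cn(CC(=O)NC(=O)Nc4ccccn4)nn3)nc(Nc3cccc(Cl)c3)c2C#N)cc1` — > 64000 nM, a limit of this assay, not a number
compound 2 `COc1cc(-c2nc(SCc3cn(CC(=O)NC(=O)Nc4ccccn4)nn3)nc(Nc3ccc(C(C)C)cc3)c2C#N)cc(OC)c1OC` — 35500 nM
compound 3 `COc1cc(-c2nc(SCc3cn(CC(=O)NC(=O)Nc4ccccn4)nn3)nc(Nc3cccc(C(F)(F)F)c3)c2C#N)cc(OC)c1OC` — 8210 nM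

Among the measured compounds shown here, compound 3 holds the lowest of the two numbers; the nearest, compound 2, sits higher by a 4.3-fold lower number from compound 2 to compound 3 (0.64 log units; beyond the scatter), the one measured step at the aryl on the amino nitrogen of the shared core. Compound 4 `COc1cc(-c2nc(SCc3cn(CC(=O)NC(=O)Nc4ccccn4)nn3)nc(Nc3cccc(Cl)c3)c2C#N)cc(OC)c1OC` differs from compound 3 by chloro in place of trifluoromethyl on an aromatic carbon. For the measured compounds named here, compound 1 also carries a 3-chlorophenyl there but differs at the other aryl, so its limit gives no step toward compound 4. Going by the values given here, only the step from compound 2 to compound 3 bears on the change, and it is modest; a step of similar or smaller size, direction uncertain, is expected. Compound 4 is estimated at 12000 nM (range 4000 nM to 40000 nM), a step of a 1.5-fold higher number from compound 3 to compound 4 (0.16 log units; within the scatter).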

Compound 4, half-maximal inhibitory concentration: 15400 nM
The estimate for compound 4 lay 1.3-fold (0.11 log units) below the measured number; the range from low to high includes it.
By their numbers in this assay, from the lowest: compounds 3 and 4 (each within the scatter of the next); then compound 2. At a limit, above all of these: compound 1.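

In this assay the exchange of trifluoromethyl for chloro gives a 1.9-fold higher number from compound 3 to compound 4 (0.27 log units; within the scatter) and so does not separate the two groups at this position. Against 4-isopropylphenyl on the nitrogen, 3-chlorophenyl gives a 2.3-fold lower number from compound 2 to compound 4 (0.36 log units; beyond the scatter) as well, so the step seen with 3-(trifluoromethyl)phenyl is not confined to that group. With 3-chlorophenyl fixed, 3,4,5-trimethoxyphenyl in place of 4-isopropylphenyl gives an at least 4.1-fold lower number from compound 1 to compound 4 (0.61 log units; beyond the scatter) and compound 1 is a limit, not a number: the limit of > 64000 nM in this assay, at which 1 of the 4 values shown sits.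

Open, on these data alone, is how an unsubstituted phenyl, 3-methoxyphenyl or 3-aminophenyl on the nitrogen would compare. Also open, as far as these compounds go, is whether any group there moves the number clearly away from compounds 3 and 4.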